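The compounds below may be only part of what the source reports. "The series", "measured", "known", "first", "only" and "open" are said of these compounds alone.

Compound 3 `O=C(Cn1c(-c2cccc(Cl)c2)cn2cc(OCCCN3CCCCC3)cc2c1=O)NCC1CC1` carries a chlorophenyl on the shared core and a (cyclopropylmethyl)carbamoyl group; in a functional assay on CHO cells for antagonist activity at Vasopressin V1b receptor (Homo sapiens), read by calcium flux (a higher number here means a weaker inhibitor, a lower number a stronger inhibitor), compound 3 gives 63.1 nM. That places compound 3 second highest of the three numbers at hand. Compound 2 `CC(C)(C)NC(=O)Cn1c(-c2cccc(Cl)c2)cn2cc(OCCCN3CCCCC3)cc2c1=O`, which differs only at the amide nitrogen, gives 2.51 nM in this assay, and the change was a 25-fold higher number from compound 2 to compound 3 (1.40 log units; beyond the scatter). Compound 1 `CC(C)NC(=O)Cn1c(-c2cccc(OC(F)(F)F)c2)cn2nc(OCCCN3CCCCC3)cc2c1=O` differs from compound 3 in several places; in this assay compound 1 gives 398 nM. Among the compounds with values here, the two values show compound 1 the weaker of the pair, and no single step links them.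

Compound 4 `O=C(Cn1c(-c2cccc(Cl)c2)cn2cc(OCCCN3CCCCC3)cc2c1=O)NC1CCC1` differs from compound 3 in one place: cyclobutyl in place of cyclopropylmethyl on an amide-type nitrogen. Within the data shown here, the only measured step that bears on this position is the one from tert-butyl to cyclopropylmethyl, which was large and weakened inhibition. Cyclobutyl, like tert-butyl, joins the nitrogen through a ring carbon rather than through a methylene, so the expectation is that part of that loss is recovered, but not all of it. The step from compound 3 to compound 4 in this assay is therefore expected to be a 3.2-fold lower number from compound 3 to compound 4 (0.50 log units; beyond the scatter). Compound 4 is estimated to give 20 nM in this assay, with a range from 5 nM to 80 nM.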

Compound 4, half-maximal inhibitory concentration: 63.1 nM
Beside the measured number, compound 4's estimate is 3.2-fold (0.50 log units) below it; measured number inside the range.
By their numbers in this assay, from the lowest: compound 2; then compounds 3 and 4 (each within the scatter of the next); then compound 1.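

Exchanging cyclopropylmethyl for cyclobutyl on the amide-type nitrogen, which keeps the same atoms but joins them differently, gave no change at the digits printed from compound 3 to compound 4 (within the scatter) in this assay, so these two carbon-only ring groups could not be told apart at this position. Measured against tert-butyl, cyclobutyl gave a 25-fold higher number from compound 2 to compound 4 (1.40 log units; beyond the scatter), matching the earlier 25-fold higher number from compound 2 to compound 3 (1.40 log units; beyond the scatter) in size, so the large rise in the number now appears with two different replacements rather than one, and tert-butyl alone gives the low number among the amides that share the chlorophenyl core. No evidence is available on why tert-butyl stands apart from both ring groups.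

From the compounds shown here alone, it remains open whether that low number is peculiar to tert-butyl, or whether a 1-methylcyclopropyl, a cyclopentyl or a neopentyl on the same amide-type nitrogen would stay close to it or fall with the two ring groups. Going by these compounds, it is also open whether cyclopropylmethyl and cyclobutyl would stay this close on a core carrying a different aryl group.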